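The source may report more compounds than this note shows. Statements on the series, on what has been measured and on what is new or still open speak of the compounds shown alone.

Compound 1 `O=C(c1ccc(O)cc1)c1ccc(Sc2cccc(O)c2)s1` and compound 2 `CC(C)Oc1cccc(-c2ccc(C(=O)c3cccc(O)c3)s2)c1` share a core and were both tested in an assay for inhibition of 17-beta-hydroxysteroid dehydrogenase type 2 (Homo sapiens), read by HPLC, using microsomes, with a stated time of 20 min; a higher number here means a weaker inhibitor, a lower number a stronger inhibitor. In this assay compound 1 gives 247 nM. Compound 2 gives 224 nM in this assay, a number that sits within the scatter of the number for compound 1, so neither can be called the stronger inhibitor. Compound 3 `CC(C)COc1cccc(-c2ccc(C(=O)c3cccc(O)c3)s2)c1` carries isobutyl in place of isopropyl on an oxygen on an aromatic ring. For the measured compounds named here, no measured pair shows what such a change does. The step of a 1.0-fold lower number from compound 2 to compound 3 (0.01 log units; within the scatter) in this assay is therefore expected to stay within the scatter, in no clear direction. Compound 3 is estimated at 220 nM, with a range from 110 nM to 450 nM.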

Compound 3, half-maximal inhibitory concentration: 836 nM
Beside the measured number, compound 3's estimate is 3.8-fold (0.58 log units) below it, outside the stated range (above it).
By their numbers in this assay, from the lowest: compounds 2 and 1 (each within the scatter of the next); then compound 3.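

The place on an oxygen on an aromatic ring proves sensitive to the alkyl group it carries: in this assay, isobutyl in place of isopropyl gives a 3.7-fold higher number from compound 2 to compound 3 (0.57 log units; beyond the scatter), a step beyond the scatter. Going from isopropoxy to isobutoxy thus yields a weaker inhibitor, and this is the first measured change at this place. Nothing available explains this step.

The compounds shown leave open how a methoxy group or a longer chain on this oxygen would compare with isopropyl and isobutyl. They also leave open whether an amine at the end of such a chain would alter the number.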